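Benzylidene series on the shared core: a para methylsulfanyl analogue

The source may report more compounds than this note shows. Statements on the series, on what has been measured and on what is new or still open speak of the compounds shown alone.

Measured so far:
compound 1 `Oc1cccc(/C=C2\CCCN=C2c2cccnc2)c1`: 1170 nM
compound 2 `C(=C1\CCCN=C1c1cccnc1)\c1ccc2c(c1)OCCO2`: 520 nM
compound 3 `C(=C1\CCCN=C1c1cccnc1)\c1ccc(-n2ccnn2)cc1`: 520 nM

In an assay on membranes from brain for displacement of a labelled ligand from Neuronal acetylcholine receptor; alpha4/beta2 (Rattus norvegicus), with a stated time of 3 h (on this read-out higher numbers stand for weaker inhibition and lower numbers for stronger inhibition), compound 3 gives 520 nM, level with compound 2 at the digits shown and, with it, the lowest of the three numbers; compound 1 sits at a higher number, beyond the scatter. Compound 4 `CSc1ccc(/C=C2\CCCN=C2c2cccnc2)cc1` carries methylsulfanyl in place of 1H-1,2,3-triazol-1-yl on an aromatic carbon. Among the measured compounds shown here, no step between measured compounds isolates a change of this kind, so the expectation rests on compound 3 alone. A small step is expected from compound 3 to compound 4, a 1.3-fold higher number from compound 3 to compound 4 (0.13 log units; within the scatter), towards a slightly higher number but likely within the scatter. For compound 4 in this assay an estimate of 700 nM is made, within 250 nM to 2000 nM.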

Compound 4, inhibition constant: 900 nM
For compound 4 the middle estimate is 1.3-fold (0.11 log units) below the measured one, and the stated range covers the measured number.
By their numbers in this assay, from the lowest: compounds 2, 3, 4 and 1 (each within the scatter of the next, the first and the last beyond it).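

In this assay, methylsulfanyl in place of 1H-1,2,3-triazol-1-yl on an aromatic carbon, para to a large group, gives a 1.7-fold higher number from compound 3 to compound 4 (0.24 log units; within the scatter). This position therefore accepts a group with no ring and fewer heavy atoms, so the five-membered aromatic ring is not required for a number in this range. No available evidence bears on the reason for this result.

As far as these compounds go, whether an amine, a carboxylic acid or a longer chain at this place stays within the scatter of compound 3 remains open. So does whether methoxy, the oxygen counterpart of methylsulfanyl, matches compound 4.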